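Swapping Hydroxy for Dimethylamino: What to Expect

A few compounds are considered here, and "the series" means these few. Any claim that something is new, unique, unknown or untested is made for them only; others in the source may bear on it.

Values measured in a functional assay on ZR-75-1 cells (Homo sapiens) for inhibition, read by sulforhodamine B assay; on this read-out higher numbers stand for weaker inhibition of growth and lower numbers for stronger inhibition of growth:
- compound 1 `c1ccc(-c2ccc(-c3ccc(-c4nc5ccccc5[nH]4)cc3)cc2)cc1`: 100000 nM
- compound 2 `Cc1ccc2[nH]c(-c3ccc(-c4ccc(-c5ccc(N(C)C)cc5)cc4)cc3)nc2c1`: 7200 nM
- compound 3 `Oc1ccc(-c2ccc(-c3ccc(-c4nc5ccccc5[nH]4)cc3)cc2)cc1`: 100000 nM

Compound 3 sits level with compound 1, and these two share the highest number of the three, so they show the weakest growth inhibition measured here. Compound 2 lies well below both of them.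

The next molecule is compound 4 `CN(C)c1ccc(-c2ccc(-c3ccc(-c4nc5ccccc5[nH]4)cc3)cc2)cc1`, which has dimethylamino in place of hydroxy on an aromatic carbon, para to a large group (dimethylamino in place of hydroxy on an aromatic carbon).

Within the data shown here, only one measured step changes a single place, and it adds the hydroxy group to the core of compound 1: no change at the digits printed from compound 1 to compound 3 (within the scatter). That step says little about the new group, since it does not involve dimethylamino. The better guide is compound 2, which carries the same dimethylamino group and gives 7200 nM. However, compound 2 also has an extra methyl on its core, and no measurement separates the contributions of these two features.

A sizeable drop in the number, meaning stronger inhibition, therefore seems likely, though with real uncertainty. The expected change is an 8.3-fold lower number from compound 3 to compound 4 (0.92 log units; beyond the scatter). For compound 4 the estimated value is 12000 nM, with an expected range from 3000 nM to 50000 nM.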

Compound 4, concentration for 50% growth inhibition: 100000 nM
For compound 4 the middle estimate is 8.3-fold (0.92 log units) below the measured one, and the stated range ends below it.
By their numbers in this assay, from the lowest: compound 2; then compounds 1, 3 and 4 (each within the scatter of the next).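

In this assay, swapping hydroxy for dimethylamino on this aromatic carbon, para to a large group, brings no change at the digits printed from compound 3 to compound 4 (within the scatter) while putting dimethylamino where hydrogen stood brings no change at the digits printed from compound 1 to compound 4 (within the scatter) and so, on this core, dimethylamino alone does not lower the number. Taking away only the methyl on an aromatic carbon brings a 14-fold higher number from compound 2 to compound 4 (1.14 log units; beyond the scatter) and this single change separates the two features that compound 2 carried together, showing that its lower number depends on the methyl being present as well as dimethylamino. No measurement at hand explains why this methyl matters.

The compounds shown leave open whether the methyl would lower the number without dimethylamino at the far end of the molecule, or whether it works only in combination with that group. They also leave open whether a methoxy group, a primary amine or a carboxylic acid at this same place, paired with the methyl on the core, would give a number closer to that of compound 2 or to that of compound 4.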